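This account rests on a few compounds, and the source may have more. Where it says the series, first, only, none or still open, it means among the compounds named here.

Of the compounds shown here, two have been measured in an ADME assay on the whole organism with Oryza sativa as the target, tested at 0.1 uM; a higher number here means a weaker effect of the compound at the concentration tested, a lower number a stronger effect. Compound 1, `C[C@H](NC(=O)Nc1cccc(F)c1)c1ccccc1`, gives 97% in this assay. Compound 2, `C[C@@H](NC(=O)Nc1cc(F)cc(F)c1)c1ccccc1`, gives 98% in this assay. The two numbers lie within the usual scatter of each other, so neither compound can be said to act more strongly than the other at the concentration tested; both leave the read-out nearly untouched.

Among the compounds with values here, the step followed here leads from compound 2 to compound 3, `C[C@H](NC(=O)Nc1cc(F)cc(F)c1)c1ccccc1`. the two compounds have the same atoms and bonds and differ only in configuration as drawn: 1 of 1 stereo elements differ; a stereocentre at a saturated chain carbon is drawn R in compound 2 and S in compound 3 No step between two measured compounds is available for guidance, and compound 1 differs from compound 2 in more than one place, so nothing measured shows how a change in configuration alone plays out. What the data do show is that compound 2, with 98%, and compound 1, with 97%, both sit near the top of the scale, leaving little room for a weaker effect. The expected step from compound 2 to compound 3 is a number 3 percentage points lower from compound 2 to compound 3 (within the scatter), that is, no change beyond the scatter. Compound 3 is accordingly expected to give 95% in this assay, within a range from 85% to 100%.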

Compound 3, a percentage reported as activity, at one concentration (the size of the read-out at that concentration, not a potency): 99%
Compound 3: middle estimate off by 4 percentage points, on the low side, within the range that was stated.
By their numbers in this assay, from the lowest: compounds 1, 2 and 3 (each within the scatter of the next).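

In this assay, within the data shown here, the step reads a number 1 percentage points higher from compound 2 to compound 3 (within the scatter), which is the first reading of this stereocentre taken on its own, and it shows that drawing the centre S rather than R gives a number that cannot be told apart from the earlier one. Among these compounds, the second step, a number 2 percentage points higher from compound 1 to compound 3 (within the scatter), is likewise the first reading of fluoro in place of hydrogen on an aromatic carbon, and this change also stays inside the scatter. All three compounds sit near the top of the scale, so these readings say only that neither change brings out an effect at the concentration tested, and the reading of configuration is a clean one: the fact that compounds 2 and 3 differ only in the configuration as drawn

From the compounds shown here alone, what stays open is whether the aromatic ring would respond to a different kind of group, such as an amine or a carboxylic acid, or whether a longer chain at the stereocentre would move the number at all. Going by these compounds, it is also open whether R and S would still give matching numbers in a compound that acts strongly enough to lower the read-out clearly.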